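Swapping a nitrile for an ethynyl on a thiazole amide

The source may hold more compounds than are shown below. What is called first, only, known or untested is meant among the compounds shown, and "the series" means these compounds.

Of the compounds shown here, three have been tested in a functional assay on BMDM cells (Mus musculus, strain C57BL/6) for inhibition, with a stated time of 2 days (on this read-out lower numbers stand for stronger inhibition and higher numbers for weaker inhibition), and a fourth, compound 4 `C#Cc1ccc(-c2cn(CC(=O)Nc3nccs3)nn2)cc1`, awaits its measurement. Compound 1 `Cc1cc(NC(=O)Cn2cc(-c3ccc(C#N)cc3)nn2)no1` gives 9320 nM in this assay. Compound 2 `C#Cc1ccc(-c2cn(CC(=O)Nc3cc(C)on3)nn2)cc1` differs from compound 1 by ethynyl in place of cyano on an aromatic carbon and in this assay compound 2 reaches only the assay limit of > 30000 nM. The step of an at least 3.2-fold higher number from compound 1 to compound 2 (0.50 log units; beyond the scatter) rests on (the limit of > 30000 nM in this assay, at which 1 of the 3 values shown sits). Compound 3 `N#Cc1ccc(-c2cn(CC(=O)Nc3nccs3)nn2)cc1` carries a different core, the difference being (1,3-thiazol-2-yl in place of 5-methyl-1,2-oxazol-3-yl on an amide-type nitrogen), and in this assay compound 3 gives 270 nM, a step of a 35-fold lower number from compound 1 to compound 3 (1.54 log units; beyond the scatter), the largest seen here.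

Compound 4 is made from compound 3 by ethynyl in place of cyano on an aromatic carbon, the same change as from compound 1 to compound 2, at the same place. The earlier step of an at least 3.2-fold higher number from compound 1 to compound 2 (0.50 log units; beyond the scatter) gives the measure for what is expected here. The step from compound 3 to compound 4 is expected to be a 7.4-fold higher number from compound 3 to compound 4 (0.87 log units; beyond the scatter). Compound 4 is therefore estimated to give about 2000 nM in this assay, most likely between 600 nM and 8000 nM.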

Compound 4, half-maximal inhibitory concentration: > 30000 nM
Compound 4 gave a limit, no number; the forecaster's own chance of this, stated with the estimate: 10%; middle value at least 15-fold (1.17 log units) from the limit.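

Compound 4 stops at the assay limit of > 30000 nM in this assay, so this value is a limit and not a number. Ethynyl in place of cyano on an aromatic carbon gives an at least 110-fold higher number from compound 3 to compound 4 (2.04 log units; beyond the scatter), which means that inhibition weakens on the core of compound 3 just as it does on the core of compound 1, so the direction of the change carries over in these two pairs. The true size of the change on either core stays hidden and the step between compound 2 and compound 4 cannot be read, so nothing shows that one core responds more strongly than the other: the same change on two cores in this assay, an at least 3.2-fold higher number (0.50 log units; beyond the scatter) from compound 1 to compound 2 and an at least 110-fold higher number (2.04 log units; beyond the scatter) from compound 3 to compound 4; the limit leaves it open whether they differ.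

The compounds shown leave open whether inhibition at this place on the ring needs the cyano group itself or could also be kept with a different group, such as a carboxylic acid or an amine. Also open, from the compounds shown here alone, is how other groups on the amide nitrogen, such as a longer carbon chain, would behave alongside cyano or ethynyl.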